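Swapping trifluoromethyl for trifluoromethoxy on the terminal ring

The source may hold more compounds than are shown below. What is called first, only, known or untested is meant among the compounds shown, and "the series" means these compounds.

The compounds measured in a functional assay on ZR-75-1 cells (Homo sapiens) for inhibition, read by sulforhodamine B assay (a lower number here means a stronger inhibitor of growth, a higher number a weaker inhibitor of growth), are these
compound 1 `Cc1ccc2[nH]c(-c3ccc(-c4ccc(-c5ccc(N(C)C)cc5)cc4)cc3)nc2c1` at 7200 nM
compound 2 `Cc1ccc2[nH]c(-c3ccc(-c4ccc(-c5cccc(Cl)c5)cc4)cc3)nc2c1` at 3450 nM
compound 3 `Cc1ccc2[nH]c(-c3ccc(-c4ccc(-c5ccc(C(F)(F)F)cc5)cc4)cc3)nc2c1` at 2410 nM

Compound 3, at 2410 nM in this assay, cannot be told apart from compound 2: the record shows a 1.4-fold lower number from compound 2 to compound 3 (0.16 log units; within the scatter) as the gap between them. Both have lower numbers than compound 1, and the record shows a 3.0-fold lower number from compound 1 to compound 3 (0.48 log units; beyond the scatter) as the larger of the two steps reaching compound 3.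

Compound 4 `Cc1ccc2[nH]c(-c3ccc(-c4ccc(-c5ccc(OC(F)(F)F)cc5)cc4)cc3)nc2c1` carries trifluoromethoxy in place of trifluoromethyl on an aromatic carbon, para to a large group, as trifluoromethoxy in place of trifluoromethyl on an aromatic carbon sets out. Among the compounds with values here, no measured step makes this exchange. The closest evidence is a 3.0-fold lower number from compound 1 to compound 3 (0.48 log units; beyond the scatter) at the same place, a modest step from a dimethylamino group, and a 2.1-fold lower number from compound 1 to compound 2 (0.32 log units; beyond the scatter), also modest. Two such different replacements moved the number only modestly, so a closer exchange is expected to produce no step beyond the scatter. The estimated step is a 1.0-fold higher number from compound 3 to compound 4 (0.02 log units; within the scatter) in this reading. For compound 4 the expected value is 2500 nM, with an estimated range from 1200 nM to 5000 nM for the measurement.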

Compound 4, concentration for 50% growth inhibition: 2410 nM
Beside the measured number, compound 4's estimate is 1.0-fold (0.02 log units) above it; low and high end bracket the measured number.
By their numbers in this assay, from the lowest: compounds 3, 4 and 2 (each within the scatter of the next); then compound 1.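

In this assay, within the data shown here, the oxygen that trifluoromethoxy adds at this position leaves the number in place, with no change at the digits printed from compound 3 to compound 4 (within the scatter) as the first direct reading of this exchange. The new group also cannot be told apart from the 3-chlorophenyl arrangement, with a 1.4-fold lower number from compound 2 to compound 4 (0.16 log units; within the scatter) as the gap, while trifluoromethoxy keeps the same separation from the dimethylamino group that trifluoromethyl showed, with a 3.0-fold lower number from compound 1 to compound 4 (0.48 log units; beyond the scatter) as the step. Nothing measured here explains why trifluoromethyl and trifluoromethoxy read alike.

The compounds shown leave open whether a longer chain on the oxygen, such as ethoxy or butoxy, would stay level with these two groups. They also leave open how a carboxylic acid, a nitrile or a primary amine would read at this position.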